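Swapping the amino group of compound 2 for methoxymethyl

The source may hold more compounds than are shown below. What is called first, only, known or untested is meant among the compounds shown, and "the series" means these compounds.

Of the compounds shown here, two with a shared core have been measured in a functional assay on U-87MG ATCC cells (Homo sapiens) for antiproliferative activity; on this read-out higher numbers stand for weaker inhibition and lower numbers for stronger inhibition. There, compound 1 `CC(=O)N1CCc2c(C)c3c(n2-c2ccc(C(N)=O)c(c2)N[C@@H](C)[C@H](C)C1)CC(C)(C)CC3=O` gives 24 nM, and compound 2 `Cc1c2c(n3c1CCN(C(=O)CN)C[C@@H](C)[C@H](C)Nc1cc-3ccc1C(N)=O)CC(C)(C)CC2=O` gives 378 nM, the higher of the two numbers and so the weaker inhibition of the pair. Compound 3 `COCCC(=O)N1CCc2c(C)c3c(n2-c2ccc(C(N)=O)c(c2)N[C@@H](C)[C@H](C)C1)CC(C)(C)CC3=O` has not yet been measured. It differs from compound 2 by methoxymethyl in place of amino on a saturated chain carbon bound to a carbonyl carbon. For the measured compounds named here, only one measured step bears on this change. Amino in place of hydrogen on such a carbon gave a 16-fold higher number from compound 1 to compound 2 (1.20 log units; beyond the scatter), a large rise beyond the scatter, and that same amino group now leaves. Going by the values given here, its loss suggests that the number should come back down, but methoxymethyl rather than hydrogen enters, and no measured compound carries that group. The expected change is a 5.4-fold lower number from compound 2 to compound 3 (0.73 log units; beyond the scatter), a fall somewhat smaller than the earlier rise. For compound 3 the estimate is 70 nM, with an expected range of 20 nM to 250 nM.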

Compound 3, half-maximal inhibitory concentration: 54 nM
Beside the measured number, compound 3's estimate is 1.3-fold (0.11 log units) above it; the range from low to high includes it.
By their numbers in this assay, from the lowest: compound 1; then compound 3; then compound 2.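

In this assay the change gives a 7.0-fold lower number from compound 2 to compound 3 (0.85 log units; beyond the scatter) and so recovers much of the rise brought by the amino group on this saturated chain carbon bound to a carbonyl carbon. Set against hydrogen at the same place, methoxymethyl gives a 2.3-fold higher number from compound 1 to compound 3 (0.35 log units; beyond the scatter) as a smaller rise than a 16-fold higher number from compound 1 to compound 2 (1.20 log units; beyond the scatter) and shows that the position does not respond to every added group alike, although hydrogen still gives the lowest number of the three compounds. Nothing given here explains why amino and methoxymethyl differ at this position.

Amino and methoxymethyl differ at once in their atoms, their size and their hydrogen-bond donors, so the compounds shown cannot separate the effect of the nitrogen from that of the chain length. A hydroxyl group, a plain ethyl chain, a dimethylamino group or a carboxylic acid on the same carbon would show whether the number follows the chain length or the kind of atom it carries.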